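The source may hold more compounds than are shown below. What is called first, only, known or untested is meant among the compounds shown, and "the series" means these compounds.

Measured compounds

Compound 1 `CC(C)[C@H](NC(=O)c1cc(Cl)ccc1OCCCNC(=O)OC(C)(C)C)C(=O)Nc1ccc([N+](=O)[O-])cc1Cl` gives > 10000 nM in a functional assay on MDA-MB-231 cells (Homo sapiens) for inhibition, read by MTT assay, with a stated time of 72 h; on this read-out higher numbers stand for weaker inhibition and lower numbers for stronger inhibition; for compound 1 this is a limit of the assay, not a number.
Compound 2 `CC(C)[C@H](NC(=O)c1cc(Cl)ccc1OCCCN)C(=O)Nc1ccc([N+](=O)[O-])cc1Cl` gives 6770 nM in this assay.
Compound 3 `CC(C)[C@H](NC(=O)c1cc(Cl)ccc1OCCNC(=O)OC(C)(C)C)C(=O)Nc1cc(C(F)(F)F)cc(C(F)(F)F)c1` gives > 10000 nM in this assay; for compound 3 this is a limit of the assay, not a number.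

Notes

One change is measured once within the series: hydrogen in place of tert-butoxycarbonyl on an amine nitrogen. It gives an at least 1.4-fold lower number from compound 1 to compound 2 (0.16 log units; that floor lies within the scatter). That this step is known only as a floor follows from the limit of > 10000 nM in this assay, at which 2 of the 3 values shown sit. The step is therefore of unknown true size; the floor itself sits within the usual scatter.

Compound 4 `CC(C)[C@H](NC(=O)c1cc(Cl)ccc1OCCN)C(=O)Nc1cc(C(F)(F)F)cc(C(F)(F)F)c1` has not yet been measured in this assay. It arises from compound 3 by the same change, (hydrogen in place of tert-butoxycarbonyl on an amine nitrogen); the place of the change reads the same in both pairs. How the core of compound 3 differs from the core of compound 1 is not broken down here.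

Compound 3 sits at the limit of the assay, so the step to compound 4 cannot be set against a number. The expectation for compound 4 rests on compound 1 and compound 2, whose step an at least 1.4-fold lower number from compound 1 to compound 2 (0.16 log units; that floor lies within the scatter) shows that removing the tert-butoxycarbonyl group brought a value back from the limit into the measurable range; the same is expected here, with a wide range. The expected step from compound 3 to compound 4 is an at least 1.1-fold lower number from compound 3 to compound 4 (0.04 log units; that floor lies within the scatter). Compound 4 is estimated at 9000 nM, between 4000 nM and 25000 nM.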

Compound 4, half-maximal inhibitory concentration: 5430 nM
Compound 4: the middle estimate sits 1.7-fold (0.22 log units) above what was measured; measured number inside the range.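

On both cores the same change, hydrogen in place of tert-butoxycarbonyl on an amine nitrogen, leads from a limit to a measured number in this assay, and on the second core it gives an at least 1.8-fold lower number from compound 3 to compound 4 (0.26 log units; that floor lies within the scatter). Set side by side, the two steps read: the same change on two cores in this assay, an at least 1.4-fold lower number (0.16 log units; that floor lies within the scatter) from compound 1 to compound 2 and an at least 1.8-fold lower number (0.26 log units; that floor lies within the scatter) from compound 3 to compound 4; the limit leaves it open whether they differ

Each step starts from a limit of the assay, so each is known only as a floor and neither has a known true size: the limit of > 10000 nM in this assay, at which 2 of the 4 values shown sit.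

The series therefore shows that the change reads in the same direction on the two cores shown, but not that it has the same size on both, nor that its size lies beyond the scatter, and how the core of compound 3 differs from the core of compound 1 remains unresolved in these notes.

What the compounds shown leave open is how other groups on that nitrogen, such as acetyl or methyl, would read in this assay, and whether a carboxylic acid in place of the amine would read the same. Also open, going by these compounds, is whether the change would carry over to a core that differs from these two in one place only, for instance by a longer chain alone.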